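Trifluoromethyl for methoxycarbonyl: from compound 2 to compound 3

The source may report more compounds than this note shows. Statements on the series, on what has been measured and on what is new or still open speak of the compounds shown alone.

Values measured in a toxicity assay on HEK293 cells (Homo sapiens) for inhibition, read by MTT assay, with a stated time of 72 h (on this read-out lower numbers stand for stronger inhibition and higher numbers for weaker inhibition), are as follows:
- compound 1 `Cc1ccc(NC(=O)CCCn2cc(-c3ccc(C(F)(F)F)cc3)nn2)cc1` gives > 100000 nM (a limit)
- compound 2 `COC(=O)c1ccc(-c2cn(CCCC(=O)Nc3ccc(-c4ccccc4)cc3)nn2)cc1` gives > 100000 nM (a limit)

Compound 2 stands at > 100000 nM as a limit and not as a number. Among the compounds with values here, the picture across the series so far is the limit of > 100000 nM in this assay, at which 2 of the 2 values shown sit, and no ranking of the two measured compounds can be drawn from it.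

Compound 3 `O=C(CCCn1cc(-c2ccc(C(F)(F)F)cc2)nn1)Nc1ccc(-c2ccccc2)cc1` differs from compound 2 in one place: trifluoromethyl in place of methoxycarbonyl on an aromatic carbon, para to a large group. The counted difference is trifluoromethyl in place of methoxycarbonyl on an aromatic carbon and the rest of the structure stays the same.

Within the data shown here, no measured step sizes such a change. With compound 2 at > 100000 nM as the only reference, no step beyond the scatter is expected in this assay and no direction is favoured. Expected here is a number no higher from compound 2 to compound 3 (the limit leaves the size open) and nothing larger. For compound 3 the estimate is 100000 nM within an expected range of 40000 nM to 200000 nM and another report as a limit is the likeliest outcome.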

Compound 3, half-maximal inhibitory concentration: > 100000 nM
Compound 3: a limit, no number (the forecaster's own chance of this, stated with the estimate: 80%); the middle value sits exactly at the limit.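

In this assay, within the data shown here, compound 3 gives > 100000 nM, a limit and not a number, so no step from compound 1 or compound 2 to compound 3 can be read. The compounds shown leave open whether trifluoromethyl, methoxycarbonyl, methyl or phenyl at these places changes the read-out at all, with every value at one ceiling: the limit of > 100000 nM in this assay, at which 3 of the 3 values shown sit.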